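Methoxy to hydroxy on the aryl acrylamide series

The source may hold more compounds than are shown below. What is called first, only, known or untested is meant among the compounds shown, and "the series" means these compounds.

Measured in a functional assay on HCT-116 cells (Homo sapiens) for antiproliferative activity, read by MTT assay, with a stated time of 72 h; on this read-out lower numbers stand for stronger inhibition and higher numbers for weaker inhibition:
- compound 1 `C=CC(=O)Nc1nc(-c2ccc(C)cc2)cs1`: 15300 nM
- compound 2 `C=CC(=O)Nc1nc(-c2ccc(OC)cc2)cs1`: 8000 nM

Only these two compounds have been measured, and compound 2 lies within the scatter of compound 1. The next compound is compound 3 `C=CC(=O)Nc1nc(-c2ccc(O)cc2)cs1`, which carries hydrogen in place of methyl on an oxygen on an aromatic ring, that is, methoxy to hydroxy (hydrogen in place of methyl on an oxygen on an aromatic ring).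

Going by the values given here, one measured step bears on this change: methoxy in place of methyl on an aromatic carbon, a 1.9-fold lower number from compound 1 to compound 2 (0.28 log units; within the scatter). Among the compounds with values here, no measured compound yet shows the exchange on the oxygen itself, so this precedent is indirect. In this assay, no step beyond the scatter is expected, and no direction is favoured. The expected step is a 1.1-fold higher number from compound 2 to compound 3 (0.05 log units; within the scatter). The estimate for compound 3 is 9000 nM, with an expected range from 3500 nM to 23000 nM.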

Compound 3, half-maximal inhibitory concentration: 7100 nM
Compound 3: the middle estimate sits 1.3-fold (0.10 log units) above what was measured, within the range that was stated.
By their numbers in this assay, from the lowest: compounds 3, 2 and 1 (each within the scatter of the next, the first and the last beyond it).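

Measured on the oxygen itself in this assay the exchange of methoxy for hydroxy gives a 1.1-fold lower number from compound 2 to compound 3 (0.05 log units; within the scatter) and so stays within the scatter, which the earlier indirect precedent could only suggest. Going by these compounds alone, the step of a 2.2-fold lower number from compound 1 to compound 3 (0.33 log units; beyond the scatter) is the first beyond the scatter, although modest, so hydroxy and methyl on the aromatic carbon can be told apart here, while methoxy and methyl could not. No measurement at hand accounts for either step.

On these data alone, whether an amine or a carboxylic acid in the same place would shift the number further remains open. Also open, as far as these compounds go, is whether a longer chain on the oxygen, such as ethoxy, would stay within the scatter as hydroxy does.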